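The compounds below may be only part of what the source reports. "The series", "measured", "known", "first", "only" and "open" are said of these compounds alone.

Three compounds define the picture so far. Compound 1 `COc1ccccc1C#Cc1cc(Cl)ccc1OCC(=O)O` gives 190 nM in an assay on CHO cells for displacement of a labelled ligand from prostaglandin D2 receptor 2 (Homo sapiens), read by scintillation counting; on this read-out lower numbers stand for stronger inhibition and higher numbers for weaker inhibition. Compound 3 `COC1c2ccc(C#Cc3cc(Cl)ccc3OCC(=O)O)cc2S(=O)(=O)C1(C)C` gives 21 nM in this assay, and compound 2 `O=C(O)COc1cc(F)ccc1C#Cc1ccccc1Cl` gives 4780 nM. On these numbers compound 1 stands second highest of the three: compound 3 lies beyond the scatter below it, and compound 2 lies beyond the scatter above it, so compound 1 occupies the middle ground between a clearly stronger and a clearly weaker neighbour.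

The step to compound 4 `O=C(O)COc1ccc(Cl)cc1C#Cc1ccccc1` is a single change: hydrogen in place of methoxy on an aromatic carbon. Going by the values given here, no measured pair shows this change alone, so its size has to be guessed. The other compounds give no direct guide either, since compound 2 and compound 3 each differ from compound 1 in more than one place. Her expectation is that the loss of the methoxy costs some affinity, a step of a 2.6-fold higher number from compound 1 to compound 4 (0.42 log units; beyond the scatter) in this assay, beyond the scatter but modest. Compound 4 is therefore estimated at 500 nM, with a range from 150 nM to 1800 nM.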

Compound 4, inhibition constant: 108 nM
Estimate against measurement, compound 4: 4.6-fold (0.67 log units) above; the measured number lies below the stated range.
By their numbers in this assay, from the lowest: compound 3; then compounds 4 and 1 (each within the scatter of the next); then compound 2.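

Taking the methoxy off this aromatic carbon, ortho to a large group, and leaving hydrogen gives a 1.8-fold lower number from compound 1 to compound 4 (0.25 log units; within the scatter) in this assay. The methoxy is therefore not required at this position for affinity on this read-out, and compound 4 shows that the core of compound 1 keeps its level of binding with no substituent there at all. Nothing measured here gives a reason why the two compounds read alike.

Going by these compounds, whether any group at this carbon can move the number beyond the scatter remains open, for instance an ethoxy, a hydroxyl or an amine. The steps to compound 2 and compound 3 cannot be read, since each differs from compound 1 in more than one place, so what separates those two from compound 4 also stays unresolved.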